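A few compounds are considered here, and "the series" means these few. Any claim that something is new, unique, unknown or untested is made for them only; others in the source may bear on it.

Working notes on esters of the shared core. In a functional assay on A549 cells (Homo sapiens) for cytotoxicity, read by MTT assay, with a stated time of 48 h (on this read-out higher numbers stand for weaker inhibition and lower numbers for stronger inhibition), compound 1 `C=C1C(=O)O[C@H]2CC3=C[C@H](C/C(C)=C/[C@@H](OC(=O)/C=C/c4ccc(N(C)C)cc4)[C@H]12)OC3=O` gives > 10000 nM, a limit and not a number. Compound 2 `C=C1C(=O)O[C@H]2CC3=C[C@H](C/C(C)=C/[C@@H](OC(=O)CCCCBr)[C@H]12)OC3=O` gives > 10000 nM, also a limit. Compound 3 `C=C1C(=O)O[C@H]2CC3=C[C@H](C/C(C)=C/[C@@H](OC(=O)CCl)[C@H]12)OC3=O` gives > 10000 nM, again a limit. Compound 3 therefore has no number of its own and stands with the other two: the limit of > 10000 nM in this assay, at which 3 of the 3 values shown sit.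

Compound 4 `C=C1C(=O)O[C@H]2CC3=C[C@H](C/C(C)=C/[C@@H](OC(=O)CC(C)C)[C@H]12)OC3=O` differs from compound 3 by isopropyl in place of chloro on a saturated chain carbon bound to a carbonyl carbon. The closest measured change, at the same place, is a step that the two limits leave unreadable from compound 2 to compound 3. Also bearing on it are a step that the two limits leave unreadable from compound 1 to compound 3 and a step that the two limits leave unreadable from compound 1 to compound 2. None of these offers a size to carry over, so no step beyond the scatter is expected in this assay, and a further limit is the likeliest report. The expected change is a step that the limit leaves unreadable from compound 3 to compound 4. Compound 4 is estimated at 15000 nM, with an expected range of 7000 nM to 40000 nM.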

Compound 4, half-maximal inhibitory concentration: 2500 nM
For compound 4 the middle estimate is 6.0-fold (0.78 log units) above the measured one; the whole stated range lies above it.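

For the compounds shown here, the change of chloro to isopropyl on a saturated chain carbon bound to a carbonyl carbon gives an at least 4.0-fold lower number from compound 3 to compound 4 (0.60 log units; beyond the scatter) in this assay, so this place can move the read-out, which the earlier compounds could not show. The isobutyl ester of compound 4 also separates from the other two esters, with an at least 4.0-fold lower number from compound 2 to compound 4 (0.60 log units; beyond the scatter) and an at least 4.0-fold lower number from compound 1 to compound 4 (0.60 log units; beyond the scatter), and all three sizes are only minimum sizes. The steps among compound 1, compound 2 and compound 3 cannot be read, and compound 4 alone carries a number: the limit of > 10000 nM in this assay, at which 3 of the 4 values shown sit.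

From the compounds shown here alone, whether a longer alkyl chain, a cyclohexyl group or an amine on the same saturated chain carbon would lower the number further stays open. Going by these compounds, the true size of each step also stays open, and a single number gives no order among groups.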